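Series notes: adding an aryl group to compound 3

A few compounds are considered here, and "the series" means these few. Any claim that something is new, unique, unknown or untested is made for them only; others in the source may bear on it.

compound 1 `CC(C)=CCc1cccc(C(=O)Nc2cc3ccc(OC4CCN(C)CC4)c(C)c3oc2=O)c1` gives 2100 nM
compound 2 `CC(=O)Oc1ccc(C(=O)Nc2cc3ccc(OC4CCN(C)CC4)c(C)c3oc2=O)cc1Cl` gives 1610 nM
compound 3 `Cc1c(OC2CCN(C)CC2)ccc2cc(NC(=O)c3ccc(O)cc3)c(=O)oc12` gives 1430 nM

These values come from a functional assay on MCF7 cells (Homo sapiens) for antiproliferative activity (a lower number here means a stronger inhibitor, a higher number a weaker inhibitor), and compound 3 is not separated from the other two: the steps of a 1.5-fold lower number from compound 1 to compound 3 (0.17 log units; within the scatter) and a 1.1-fold lower number from compound 2 to compound 3 (0.05 log units; within the scatter) both stay within the scatter, as does a 1.3-fold lower number from compound 1 to compound 2 (0.12 log units; within the scatter) among the others.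

Compound 4 `COc1cccc(-c2cc(C(=O)Nc3cc4ccc(OC5CCN(C)CC5)c(C)c4oc3=O)ccc2O)c1` has 3-methoxyphenyl in place of hydrogen on an aromatic carbon, ortho to a hydroxy group (3-methoxyphenyl in place of hydrogen on an aromatic carbon). For the measured compounds named here, the three measured steps all exchange the group on the carbonyl carbon, and no measured compound carries 3-methoxyphenyl, so they guide this change only loosely. The expected result is a 1.2-fold lower number from compound 3 to compound 4 (0.08 log units; within the scatter) and thus no step beyond the scatter in this assay for now. The estimate for compound 4 is 1200 nM (expected range 400 nM to 3000 nM).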

Compound 4, half-maximal inhibitory concentration: 810 nM
The estimate for compound 4 lay 1.5-fold (0.17 log units) above the measured number; measured number inside the range.
By their numbers in this assay, from the lowest: compounds 4, 3, 2 and 1 (each within the scatter of the next, the first and the last beyond it).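

In this assay the step of a 1.8-fold lower number from compound 3 to compound 4 (0.25 log units; within the scatter) does not separate the two compounds. This position, on an aromatic carbon ortho to a hydroxy group, therefore accepts 3-methoxyphenyl, with its 8 heavy atoms and one further aromatic ring, without a step beyond the scatter. Nothing available explains this result.

As far as these compounds go, it remains open whether a phenyl ring bearing an amine or a carboxylic acid in place of methoxy would separate from compound 3 at this carbon. The same applies to a smaller group such as methyl.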